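Replacing the Ether-Linked Heterocycle on a Ketone Side Chain

The source may report more compounds than this note shows. Statements on the series, on what has been measured and on what is new or still open speak of the compounds shown alone.

Compound 1, `CC(C)[C@H](NC(=O)COc1cccc2ccccc12)C(=O)N[C@@H](CC(=O)O)C(=O)CSc1nccn1C`, gives > 200000 nM in a functional assay on Jurkat cells (Homo sapiens) for inhibition (on this read-out lower numbers stand for stronger inhibition and higher numbers for weaker inhibition), a limit.
Compound 2, `CC(C)[C@H](NC(=O)COc1cccc2ccccc12)C(=O)N[C@@H](CC(=O)O)C(=O)COc1nc2ccccc2[nH]1`, gives > 200000 nM in this assay, again a limit.
Compound 3, `CC(C)[C@H](NC(=O)COc1cccc2ccccc12)C(=O)N[C@@H](CC(=O)O)C(=O)COn1nnc2ccccc2c1=O`, gives 137000 nM in this assay.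

Going by the values given here, compound 3 thus holds the only number among the three; the other two values are limits (the limit of > 200000 nM in this assay, at which 2 of the 3 values shown sit). The step of an at least 1.4-fold lower number from compound 2 to compound 3 (0.16 log units; that floor lies within the scatter) and the step of an at least 1.4-fold lower number from compound 1 to compound 3 (0.16 log units; that floor lies within the scatter) both stop at the limit, while the step that the two limits leave unreadable from compound 1 to compound 2. Compound 4, `CC(C)[C@H](NC(=O)COc1cccc2ccccc12)C(=O)N[C@@H](CC(=O)O)C(=O)COc1[nH]cnc2nncc1-2`, differs from compound 3 by a group of 9 heavy atoms (5 carbon, 4 nitrogen; one five-membered aromatic ring with 2 hetero atoms, one six-membered aromatic ring with 2 hetero atoms) in place of a group of 11 heavy atoms (7 carbon, 3 nitrogen, 1 oxygen; one six-membered aromatic ring of carbon only, one six-membered aromatic ring with 3 hetero atoms), on an oxygen on a saturated carbon. The step from compound 2 to compound 3 bears on it, since it exchanges a heterocycle on the same oxygen, yet its size is barely readable. Compound 4 is therefore expected to stay in the same weak range, with a step of a 1.1-fold higher number from compound 3 to compound 4 (0.04 log units; within the scatter) not beyond the scatter, and its estimated value is 150000 nM, between 50000 nM and 400000 nM.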

Compound 4, half-maximal inhibitory concentration: 161000 nM
Compound 4: the middle estimate sits 1.1-fold (0.03 log units) below what was measured, within the range that was stated.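

In this assay the exchange on the oxygen gives a 1.2-fold higher number from compound 3 to compound 4 (0.07 log units; within the scatter) and so separates two different groups no further, although the entering group carries a hydrogen-bond donor and the leaving group none. Compound 4 therefore adds a second measured number at this position, in the same range as compound 3. Neither an at least 1.2-fold lower number from compound 2 to compound 4 (0.09 log units; that floor lies within the scatter) nor an at least 1.2-fold lower number from compound 1 to compound 4 (0.09 log units; that floor lies within the scatter) shows more than a floor, because compound 1 and compound 2 are limits: the limit of > 200000 nM in this assay, at which 2 of the 4 values shown sit.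

Going by these compounds, whether an amine, a carboxylic acid or a longer chain on this oxygen would move the number beyond the scatter stays open.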